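The source may report more compounds than this note shows. Statements on the series, on what has been measured and on what is new or still open speak of the compounds shown alone.

Working notes on the series.

For the measured compounds named here, compound 1 `O=S(=O)(Nc1nccs1)c1ccc2c(c1)OCC[C@@H]2c1ccc(C(F)(F)F)cc1N1CCNCC1` sits at the top of the three numbers measured so far: in a physicochemical assay for solubility (a lower number here means a less soluble compound, a higher number a more soluble compound), compound 1 gives 288000 nM. Compound 3 `Cc1ccc(-c2cc(C(F)(F)F)ccc2[C@H]2CCOc3cc(S(=O)(=O)Nc4ncc(F)cn4)ccc32)cn1` is nearest, giving 225000 nM in this assay, a gap that lies within the usual scatter, so the two read as equivalent. Compound 2 `Cn1nccc1-c1cc(C(F)(F)F)ccc1[C@H]1CCOc2cc(S(=O)(=O)Nc3cccc(F)n3)ccc21` is furthest, giving 27000 nM in this assay, a gap beyond the scatter.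

The step to compound 4 `Cc1nc(-c2cc(C(F)(F)F)ccc2[C@H]2CCOc3cc(S(=O)(=O)Nc4nccs4)ccc32)co1` is the change (2-methyl-1,3-oxazol-4-yl in place of piperazin-1-yl on an aromatic carbon). Going by the values given here, no measured pair in the set differs in exactly this way, so the size of the step has to be expected rather than read off. The two measured compounds carrying a five- or six-membered aromatic group ortho to the large group, compound 2 at 27000 nM and compound 3 at 225000 nM, span a wide interval and give no single anchor. Against that background the step from compound 1 to compound 4 is expected to run downward, a 4.1-fold lower number from compound 1 to compound 4 (0.61 log units; beyond the scatter), beyond the scatter but not as far as the lowest value in the set.

For compound 4 in this assay the estimate is 70000 nM, with a range from 18000 nM to 220000 nM.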

Compound 4, solubility: 61000 nM
Compound 4: middle estimate off by 1.1-fold (0.06 log units), on the high side, within the range that was stated.
By their numbers in this assay, from the lowest: compound 2; then compound 4; then compounds 3 and 1 (each within the scatter of the next).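

In this assay, for the compounds shown here, 2-methyl-1,3-oxazol-4-yl in place of piperazin-1-yl on this aromatic carbon, ortho to a large group and meta to a trifluoromethyl group, gives a 4.7-fold lower number from compound 1 to compound 4 (0.67 log units; beyond the scatter); this is the first reading at this position with the rest of the molecule held constant, since compound 2 and compound 3 each differ from compound 1 in more than one place. The two groups match in heavy-atom count and in hydrogen-bond acceptors, so the step comes with a change of ring type and the loss of the hydrogen-bond donor rather than with any change in those counts. No measurement here bears on what lies behind the step.

The compounds shown leave open whether the step follows the change of ring or the loss of the donor, and morpholin-4-yl on the same carbon would separate the two. Also open, going by these compounds, is whether a step of this size holds with a different group on the sulfonamide nitrogen, as carried by compound 2 and compound 3.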